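A few compounds are considered here, and "the series" means these few. Any claim that something is new, unique, unknown or untested is made for them only; others in the source may bear on it.

Working notes on the series. Of the compounds shown here, three have been measured in a physicochemical assay for lipophilicity, using the shake flask method, at pH 7.4; a lower number here means a more polar compound, a higher number a more lipophilic compound. Compound 1 `CC(C)c1c(C(=O)NCc2ccccc2)nc(-c2ccc(F)cc2)n1CC[C@@H](O)C[C@@H](O)CC(=O)O` gives 0.64. Compound 2 `Cc1ccc(CNC(=O)c2nn(-c3ccc(F)cc3)c(CC[C@@H](O)C[C@@H](O)CC(=O)O)c2C(C)C)cc1` gives 0.24. Compound 3 `Cc1cccc(CNC(=O)c2nc(-c3ccc(F)cc3)n(CC[C@@H](O)C[C@@H](O)CC(=O)O)c2C2CC2)c1` gives 0.47, the second highest of the three; its nearest neighbour is compound 1, and the gap to compound 2 also lies within the scatter, so the three values cannot be ordered with confidence. The next compound, compound 4 `O=C(O)C[C@H](O)C[C@H](O)CCn1c(-c2ccc(F)cc2)nc(C(=O)NCc2cccc(F)c2)c1C1CC1`, has not yet been measured in this assay. It differs from compound 3 by fluoro in place of methyl on an aromatic carbon. Among the compounds with values here, no measured pair shows this change, so its size is open. A small downward step, at the edge of the scatter, is expected: a number 0.22 log units lower from compound 3 to compound 4 (within the scatter). Compound 4 is accordingly estimated at 0.25, most likely between -0.15 and 0.65.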

Compound 4, distribution coefficient: 0.51
Estimate against measurement, compound 4: 0.26 log units below, within the range that was stated.
By their numbers in this assay, from the lowest: compounds 2, 3, 4 and 1 (each within the scatter of the next, the first and the last beyond it).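

In this assay, within the data shown here, the change from 3-methylbenzyl to 3-fluorobenzyl gives the first step that can be read at this position (a number 0.04 log units higher from compound 3 to compound 4 (within the scatter)). In this one pair, fluoro in place of methyl on an aromatic carbon, meta to a large group, stays within the scatter. Nothing available bears on the cause of this result.

From the compounds shown here alone, whether chloro, methoxy or an amine at this position would also stay within the scatter remains open. So does whether the same change would give a similar step on the core of compound 2.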